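A few compounds are considered here, and "the series" means these few. Any claim that something is new, unique, unknown or untested is made for them only; others in the source may bear on it.

Measured compounds:
compound 1 `CC1(C)CC(NC(=O)Nc2cccc(Cl)c2)c2cc(Br)ccc2O1` — a functional assay on B16-F10 cells (Mus musculus) for inhibition, read by MTT assay, with a stated time of 72 h; on this read-out higher numbers stand for weaker inhibition and lower numbers for stronger inhibition: "not determined" (no result reported)
compound 2 `CC1(C)CC(NC(=O)Nc2ccc(Cl)cc2)c2cc(Br)ccc2O1` — this assay: 9000 nM

Compound 1 stands without a number: in this assay compound 1 is recorded as "not determined" (no result reported), so nothing can be said of where it lies. The only measured point among these compounds is compound 2, which in this assay gives 9000 nM. Compound 3 `CC1(C)CC(NC(=O)Nc2cccc(Cl)c2)c2cc(Cl)ccc2O1` has not been tested. Compound 3 differs from compound 1 in one place: chloro in place of bromo on an aromatic carbon. Among the measured compounds shown here, no measured pair shows what such a change does, so the size and direction of the step in this assay from compound 1 to compound 3 cannot be read from the data; it is expected to stay within the scatter, or at most to be a small step either way. Resting on compound 2, compound 3 is estimated in this assay at about 10000 nM, with a range from 3000 nM to 35000 nM.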

Compound 3, half-maximal inhibitory concentration: 25000 nM
Estimate against measurement, compound 3: 2.5-fold (0.40 log units) below, and the stated range covers the measured number.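

Compound 1 has no number to set against compound 3, so no new step can be read between them. On these data alone, what chloro in place of bromo does in this assay remains open. No evidence bears on the result for compound 3.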